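Replacing 2,4-dichlorophenyl with 2,3,4-trifluorophenyl

The compounds below may be only part of what the source reports. "The series", "measured", "known", "first", "only" and "open" are said of these compounds alone.

- compound 1 `OC[C@H]1O[C@@H](n2cnc3c(NCc4ccc(Br)cc4)ncnc32)[C@H](O)[C@@H]1O` gives 47400 nM
- compound 2 `OC[C@H]1O[C@@H](n2cnc3c(NCc4ccc(Cl)cc4Cl)ncnc32)[C@H](O)[C@@H]1O` gives 96300 nM

Both values come from a functional assay on HL-60 cells (Homo sapiens) for antiproliferative activity, with a stated time of 72 h (a lower number here means a stronger inhibitor, a higher number a weaker inhibitor), and the two compounds share one core. Compound 2 holds the higher number of the pair at 96300 nM and is therefore the weaker inhibitor of the two.

The next compound to consider is compound 3 `OC[C@H]1O[C@@H](n2cnc3c(NCc4ccc(F)c(F)c4F)ncnc32)[C@H](O)[C@@H]1O` which has not yet been measured. It keeps the shared core and differs from compound 2 in one group: 2,3,4-trifluorophenyl in place of 2,4-dichlorophenyl on a saturated chain carbon bound to a nitrogen on an aromatic ring so that 2,3,4-trifluorophenyl takes the place of 2,4-dichlorophenyl on a saturated chain carbon bound to a nitrogen on an aromatic ring.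

Among the compounds with values here, only one measured step bears on this place. That step, a 2.0-fold higher number from compound 1 to compound 2 (0.31 log units; beyond the scatter) is modest, and it exchanges 4-bromophenyl for 2,4-dichlorophenyl. Within the data shown here, no compound carrying fluorine has been measured, so the direction is only weakly supported. A value between those of compound 1 and compound 2 is the plainest expectation.

The expected change is small and points to a lower number: a 1.4-fold lower number from compound 2 to compound 3 (0.14 log units; within the scatter) in this assay for this swap. For compound 3 the estimate is 70000 nM with an expected range of 28000 nM to 170000 nM around it.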

Compound 3, half-maximal inhibitory concentration: 13000 nM
Beside the measured number, compound 3's estimate is 5.4-fold (0.73 log units) above it, outside the stated range (below it).
By their numbers in this assay, from the lowest: compound 3; then compound 1; then compound 2.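

In this assay, the group on this saturated chain carbon bound to a nitrogen on an aromatic ring can move the number well beyond the scatter: 2,3,4-trifluorophenyl in place of 2,4-dichlorophenyl gives a 7.4-fold lower number from compound 2 to compound 3 (0.87 log units; beyond the scatter). The same group also improves on 4-bromophenyl, with a 3.6-fold lower number from compound 1 to compound 3 (0.56 log units; beyond the scatter), so 2,3,4-trifluorophenyl gives the lowest number of the three groups shown, and fluorine now appears at this position for the first time. Nothing available here accounts for this gain, so the result stands as an observation without an explanation.

The three groups differ in both the kind of halogen and the number and placing of halogens on the phenyl ring, so these compounds cannot show which of those differences matters. Plain phenyl, 4-fluorophenyl and a phenyl ring carrying a methoxy group or an amine would each test a different part of that question, and the effect of any such group at this position remains open.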